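Methyl on the benzoate of compound 1

The compounds below may be only part of what the source reports. "The series", "measured", "known", "first", "only" and "open" are said of these compounds alone.

Values in an ADME assay on cells (Hepatocyte, Homo sapiens) for metabolic stability, with a stated time of 30 min (a higher number here means that more of the compound is left, a lower number that less of the compound is left), so far
- compound 1 `O=C(OC1CCC(CN2CCN(c3cc(=O)c4cc(C(F)(F)F)cc([N+](=O)[O-])c4s3)CC2)CC1)c1ccccc1` gives 56.4%
- compound 2 `O=C(NC1CCC(CN2CCN(c3cc(=O)c4cc(C(F)(F)F)cc([N+](=O)[O-])c4s3)CC2)CC1)c1ccccc1` gives 92.9%
- compound 3 `O=C(OC1CCC(CN2CCN(c3cc(=O)c4cc(C(F)(F)F)cc([N+](=O)[O-])c4s3)CC2)CC1)c1ccncc1` gives 1%

Compound 1 stands second of the three, with compound 2 above it and compound 3 below it. The next case is compound 4 `Cc1ccc(C(=O)OC2CCC(CN3CCN(c4cc(=O)c5cc(C(F)(F)F)cc([N+](=O)[O-])c5s4)CC3)CC2)cc1`, whose difference from compound 1 is methyl in place of hydrogen on an aromatic carbon. The nearest evidence is pyridin-4-yl in place of phenyl on the carbonyl carbon, a large step of a number 55.4 percentage points lower from compound 1 to compound 3 (beyond the scatter) in the same part of the molecule. The step of a number 36.5 percentage points higher from compound 1 to compound 2 (beyond the scatter), also large, alters the link instead, and a number 91.9 percentage points lower from compound 2 to compound 3 (beyond the scatter) combines both changes. For the measured compounds named here, no measured compound carries a substituent on the phenyl, so the evidence is indirect. Only a small downward step in this assay is expected, probably within the scatter. The estimated step is a number 6.4 percentage points lower from compound 1 to compound 4 (within the scatter) and its size is uncertain. The expected value for compound 4 is 50%, within an estimated range of 25% to 75%.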

Compound 4, percent of the compound remaining: 9.7%
Compound 4: the middle estimate sits 40.3 percentage points above what was measured; measured number below the stated range.
By their numbers in this assay, from the lowest: compounds 3 and 4 (each within the scatter of the next); then compound 1; then compound 2.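

In this assay, a single methyl on an aromatic carbon, para to a large group, is enough for a large step (a number 46.7 percentage points lower from compound 1 to compound 4 (beyond the scatter)), so this carbon of the ester's phenyl ring is sensitive to substitution. The 4-methylphenyl and pyridin-4-yl esters stand level (a number 8.7 percentage points higher from compound 3 to compound 4 (within the scatter)), while the benzamido compound remains far apart from the methylated ester (a number 83.2 percentage points lower from compound 2 to compound 4 (beyond the scatter)).

On these data alone, whether a benzamide carrying the same 4-methyl group would keep the value of compound 2, and whether fluoro or methoxy at this carbon would act like methyl, stays open. Nothing measured on these compounds explains the drop.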